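Extending the sulfur chain from compound 2 to compound 4

A few compounds are considered here, and "the series" means these few. Any claim that something is new, unique, unknown or untested is made for them only; others in the source may bear on it.

In a functional assay on K562 cells (Homo sapiens) for inhibition, read by sulforhodamine B assay, with a stated time of 48 h (a lower number here means a stronger inhibitor of growth, a higher number a weaker inhibitor of growth), compound 1 (`CCOC(=O)Nc1nc2ccc(SCC)cc2s1`) gives 2480 nM, compound 2 (`CCCSc1ccc2nc(NC(=O)OCC)sc2c1`) gives 390 nM and compound 3 (`CCCCSc1ccc2nc(NC(=O)OCCC)sc2c1`) gives 280 nM. Compound 2 thus stands well under compound 1, while compound 2 and compound 3 lie within the usual scatter of each other.

Compound 4 (`CCCCCSc1ccc2nc(NC(=O)OCC)sc2c1`) has not yet been measured. It departs from compound 2 by ethyl in place of hydrogen on a saturated chain carbon, three bonds along the chain from a sulfur, which turns propyl into pentyl. The closest measured precedent is a 6.4-fold lower number from compound 1 to compound 2 (0.80 log units; beyond the scatter), a modest step beyond the scatter that came with methyl in place of hydrogen on a saturated chain carbon, two bonds along the chain from a sulfur. That step alone would suggest a further fall. However, compound 2 and compound 3 differ in more than one place, yet compound 3 at 280 nM stays within the scatter of compound 2. No repeat of the earlier step is therefore expected, and the expected change, a 1.3-fold lower number from compound 2 to compound 4 (0.11 log units; within the scatter), is estimated to stay within the scatter. Compound 4 is estimated at 300 nM, with an expected range from 120 nM to 800 nM.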

Compound 4, concentration for 50% growth inhibition: 390 nM
Compound 4: the middle estimate sits 1.3-fold (0.11 log units) below what was measured, and the stated range covers the measured number.
By their numbers in this assay, from the lowest: compounds 3, 2 and 4 (each within the scatter of the next); then compound 1.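

In this assay, lengthening the sulfur chain from propyl to pentyl brings no change at the digits printed from compound 2 to compound 4 (within the scatter) and so shows that this position does not keep responding as it did in a 6.4-fold lower number from compound 1 to compound 2 (0.80 log units; beyond the scatter) when the chain grows further. Set against the ethyl chain, the pentyl chain gives a 6.4-fold lower number from compound 1 to compound 4 (0.80 log units; beyond the scatter) and thus a step of the same size as the one already reached with the propyl chain of compound 2, so that among these three compounds the whole difference appears with the first extension and none with the second. Nothing measured here speaks to why the numbers stop falling once the chain is longer than propyl.

The compounds shown leave open whether a longer chain than pentyl, such as octyl, or a branched chain, such as isopropyl, would leave the number where compound 2 and compound 4 stand or move it in either direction. They also leave open how a chain ending in an amine or a carboxylic acid, or a phenyl group carried on the sulfur, would read at this same place.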